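This account rests on a few compounds, and the source may have more. Where it says the series, first, only, none or still open, it means among the compounds named here.

Measured compounds so far:

compound 1, `O=C(NCCCCl)Oc1ccc(Cl)cc1C(=O)Nc1ccc(Cl)c(Cl)c1`, gives 2500 nM in an ADME assay on MONO-MAC-6 cells (Homo sapiens) for cytotoxicity, read by MTT assay, with a stated time of 16 h; on this read-out higher numbers stand for weaker inhibition and lower numbers for stronger inhibition.
compound 2, `CCCNC(=O)Oc1ccc(Cl)cc1C(=O)Nc1ccc(Cl)c(Cl)c1`, gives 7000 nM in this assay.
compound 3, `O=C(NCCCCl)Oc1ccc(Cl)cc1C(=O)Nc1ccc(C(=O)c2ccccc2)cc1`, gives 16100 nM in this assay.

Compound 2 is compound 1 with hydrogen in place of chloro on a saturated chain carbon, three bonds along the chain from an amide-type nitrogen. That change gave a 2.8-fold higher number from compound 1 to compound 2 (0.45 log units; beyond the scatter) in this assay, a modest move toward weaker inhibition. Compound 3 carries the same 3-chloropropyl carbamate as compound 1 but on a different core; the difference between the two cores is not broken down here. On its own core compound 3 stands highest of the three numbers, clear of compound 2 and further still from compound 1.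

Compound 4, `CCCNC(=O)Oc1ccc(Cl)cc1C(=O)Nc1ccc(C(=O)c2ccccc2)cc1`, is compound 3 with hydrogen in place of chloro on a saturated chain carbon, three bonds along the chain from an amide-type nitrogen, the same change that leads from compound 1 to compound 2, made on the core of compound 3. Within the data shown here, only one prior instance of the change exists, and on a different core, so its transfer is uncertain. For compound 4 the expected step is a 2.6-fold higher number from compound 3 to compound 4 (0.42 log units; beyond the scatter) in this assay, resting on compound 1 to compound 2 having shown a 2.8-fold higher number from compound 1 to compound 2 (0.45 log units; beyond the scatter), read as a shift toward a weaker number of about that size. Compound 4 is therefore estimated at 42000 nM, with a plausible range from 16000 nM to 110000 nM. Because compound 3 already gives 16100 nM, compound 4 is expected to land at the weak end of the range covered by the measured compounds, and the estimate is correspondingly uncertain.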

Compound 4, half-maximal inhibitory concentration: 18700 nM
Compound 4: the middle estimate sits 2.2-fold (0.35 log units) above what was measured; the measured number falls inside the stated range.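

On the core of compound 3, replacing chloro with hydrogen on the saturated chain carbon, three bonds along the chain from an amide-type nitrogen, gives a 1.2-fold higher number from compound 3 to compound 4 (0.07 log units; within the scatter) in this assay, so the 3-chloropropyl and propyl carbamates cannot be told apart on this core. Set beside the earlier step, the new step shows no difference that can be separated from assay noise: the same change on two cores in this assay, a 2.8-fold higher number (0.45 log units; beyond the scatter) from compound 1 to compound 2 and a 1.2-fold higher number (0.07 log units; within the scatter) from compound 3 to compound 4, 2.4-fold (0.38 log units) apart, within the scatter of two such steps. Among these compounds, the change therefore carries across these two cores without a demonstrated core dependence, but this does not show that its size is fixed, since only one of the two steps lies beyond the scatter and two pairs are too few to establish either a shared effect or a real difference between cores.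

The compounds shown leave open whether the step seen on the core of compound 1 depends on chloro itself, a question that a fluorine, a hydroxyl group or an amine at the end of the propyl chain, or a longer chain such as butyl, could address. They also leave open whether the change behaves in the same way on a third core in this assay.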